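The compounds below may be only part of what the source reports. "The series", "measured", "known", "first", "only" and "open" are said of these compounds alone.

In a functional assay on HCT-116 cells (Homo sapiens) for inhibition, read by CCK-8 assay, with a stated time of 48 h (a higher number here means a weaker inhibitor, a lower number a stronger inhibitor), compound 1 `COc1cc(N(Cc2ccc(Br)cc2)C(=O)CSC(=S)N2CCN(C(=O)OC(C)(C)C)CC2)cc(OC)c1OC` gives 11400 nM and compound 2 `COc1ccc(CN(C(=O)CSC(=S)N2CCN(C(=O)OC(C)(C)C)CC2)c2cc(OC)c(OC)c(OC)c2)cc1F` gives 8210 nM. These two values lie within the scatter of each other, and neither compound can be ranked over the other. Compound 3 `COc1ccc(CN(C(=O)CSC(=S)N2CCN(C(=O)OC(C)(C)C)CC2)c2cc(OC)c(OC)c(OC)c2)cc1N` differs from compound 2 in one group: amino in place of fluoro on an aromatic carbon, ortho to a methoxy group (amino in place of fluoro on an aromatic carbon). Within the data shown here, only one measured step offers any guidance, a 1.4-fold lower number from compound 1 to compound 2 (0.14 log units; within the scatter), which exchanges 4-bromophenyl for 3-fluoro-4-methoxyphenyl and stays within the scatter. Among the measured compounds shown here, that is a different change, and no measured compound carries the amino group, so the guidance is weak. No step beyond the scatter is expected in this assay. The expected step is a 1.6-fold lower number from compound 2 to compound 3 (0.22 log units; within the scatter). For compound 3 the estimated value is 5000 nM, with an expected range of 1200 nM to 16000 nM.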

Compound 3, half-maximal inhibitory concentration: 352 nM
The estimate for compound 3 lay 14-fold (1.15 log units) above the measured number; the whole stated range lies above it.
By their numbers in this assay, from the lowest: compound 3; then compounds 2 and 1 (each within the scatter of the next).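

In this assay, among these compounds, amino in place of fluoro on this aromatic carbon, ortho to a methoxy group, gives a 23-fold lower number from compound 2 to compound 3 (1.37 log units; beyond the scatter) and so brings the first change beyond the scatter, showing that the number is sensitive to the group at this position. Measured against the 4-bromophenyl compound, the 3-amino-4-methoxyphenyl group gives a 32-fold lower number from compound 1 to compound 3 (1.51 log units; beyond the scatter) as a second large step, whereas 3-fluoro-4-methoxyphenyl stayed within the scatter of that same compound. No measurement here explains what the amino group does at this position.

On these data alone, it remains open whether the amino group itself is needed, since a hydroxyl, a methylamino or an acetamido group on the same carbon would each test this. The compounds shown also leave open whether an amino group would have a similar effect on any other carbon of this ring.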